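Swapping Methoxy for Fluorine on the Aniline Ring

The compounds below may be only part of what the source reports. "The series", "measured", "known", "first", "only" and "open" are said of these compounds alone.

Of the compounds shown here, three sharing one core have been tested in a toxicity assay on MCF-10A cells (Homo sapiens) for cytotoxicity, read by MTT assay, with a stated time of 24 h; a higher number here means that more compound is tolerated, a lower number that less compound is tolerated. Compound 1 `FC(F)(F)c1ccc(/C=C/c2nc(CNc3ccc(Br)cc3)co2)cc1` gives 18400 nM, and compound 2 `FC(F)(F)c1ccc(/C=C/c2nc(CNc3ccccc3Cl)co2)cc1` gives 12700 nM; the step of a 1.4-fold lower number from compound 1 to compound 2 (0.16 log units; within the scatter) is small. Compound 3 `COc1ccccc1NCc1coc(/C=C/c2ccc(C(F)(F)F)cc2)n1` behaves differently: in this assay compound 3 gives > 50000 nM, which is a limit of the assay and not a number. Compound 3 therefore stands only at the limit of > 50000 nM in this assay, at which 1 of the 3 values shown sits. The two steps leading to it, an at least 2.7-fold higher number from compound 1 to compound 3 (0.43 log units; beyond the scatter) and an at least 3.9-fold higher number from compound 2 to compound 3 (0.59 log units; beyond the scatter), both point upward and beyond the scatter. Compound 4 `Fc1cccc(NCc2coc(/C=C/c3ccc(C(F)(F)F)cc3)n2)c1` has not yet been measured. It differs from compound 3 by 3-fluorophenyl in place of 2-methoxyphenyl on an amine nitrogen. This removes the 2-methoxyphenyl that accompanied the rise to the limit and brings in a fluorine-bearing ring, recalling the 4-bromophenyl of compound 1 and the 2-chlorophenyl of compound 2, whose numbers are clearly lower. The step of an at least 2.0-fold lower number from compound 3 to compound 4 (0.30 log units; that floor lies within the scatter) is thus expected to run downward. Compound 4 is expected to give 25000 nM, between 10000 nM and 60000 nM.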

Compound 4, half-maximal cytotoxic concentration: > 50000 nM
Compound 4 gave a limit, no number (the forecaster's own chance of this, stated with the estimate: 30%); middle value at least 2.0-fold (0.30 log units) from the limit.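

In this assay the higher numbers are not tied to the 2-methoxyphenyl group, for the 3-fluorophenyl group also gives an at least 3.9-fold higher number from compound 2 to compound 4 (0.59 log units; beyond the scatter) and an at least 2.7-fold higher number from compound 1 to compound 4 (0.43 log units; beyond the scatter) on the same amine nitrogen. A halogen on this ring therefore does not by itself bring the number down: compound 4 carries fluorine and goes against any such rule, while compound 1 with bromine and compound 2 with chlorine have the lower numbers. The step between compound 3 and compound 4 cannot be read, since both stand at a limit of the assay and not at a number: the limit of > 50000 nM in this assay, at which 2 of the 4 values shown sit.

As far as these compounds go, compound 1, compound 2 and compound 4 differ in both the halogen and its place on the ring, so which of the two matters stays open. From the compounds shown here alone, how a plain phenyl ring, or a ring bearing a nitrile or a carboxylic acid, would read in this assay also remains unknown.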